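This account rests on a few compounds, and the source may have more. Where it says the series, first, only, none or still open, it means among the compounds named here.

The measured compounds are compound 1, `Cc1ccc(/C=C2\CCCC(CN(C)c3ccccc3)C2=O)cc1`, which gives 39.5% in a functional assay on the whole organism (Ear, strain Kunming) for inhibition, with Mus musculus as the target, with stated times of 1 h and 30 min, at a dose of 200 mg/kg by the oral route; on this read-out lower numbers stand for less inhibition and higher numbers for more inhibition at the one dose given (going by the name of the read-out); compound 2, `Cc1ccc(/C=C2\CCCC(CN(C)c3ccc(C)cc3)C2=O)cc1`, which gives 27.6% in this assay; and compound 3, `COc1ccc(C2(O)/C(=C/c3ccccc3)CCCC2CN(C)c2ccccc2)cc1`, which gives 26.5% in this assay.

Compound 4, `COc1ccc(C2(O)/C(=C/c3ccccc3)CCCC2CN(C)c2ccc(C)cc2)cc1`, has not yet been measured. It differs from compound 3 by methyl in place of hydrogen on an aromatic carbon. The same change has already been made once among the measured compounds: compound 2 differs from compound 1 by methyl in place of hydrogen on an aromatic carbon, and in this assay this gave a number 11.9 percentage points lower from compound 1 to compound 2 (beyond the scatter). The two place descriptions agree word for word, so the change from compound 3 to compound 4 is the same change. The difference between the core of compound 1 and the core of compound 3 is not broken down here; what can be said is that compound 3 and compound 2 give numbers within the scatter of each other, while compound 1 stands apart from both.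

Going by the values given here, with only one earlier instance of the change, the expectation for compound 4 rests on it alone: a step of about the same size and direction, because compound 1 to compound 2 showed a number 11.9 percentage points lower from compound 1 to compound 2 (beyond the scatter). The step from compound 3 to compound 4 is therefore estimated at a number 10.5 percentage points lower from compound 3 to compound 4 (beyond the scatter). Compound 4 is expected to give about 16% in this assay, within roughly 4% to 30%.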

Compound 4, a percentage reported as inhibition, in the whole organism at one dose (the size of the read-out at that dose, not a potency): 26.5%
Estimate against measurement, compound 4: 10.5 percentage points below, and the stated range covers the measured number.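

In this assay, the change from phenyl to 4-methylphenyl gave no change at the digits printed from compound 3 to compound 4 (within the scatter), while on the other core it had given a number 11.9 percentage points lower from compound 1 to compound 2 (beyond the scatter). The two steps can be read as one and the same effect, since the gap between them does not exceed what two such steps may scatter apart: the same change on two cores in this assay, a number 11.9 percentage points lower (beyond the scatter) from compound 1 to compound 2 and no change at the digits printed (within the scatter) from compound 3 to compound 4, 11.9 percentage points apart, within the scatter of two such steps

This does not show that the change carries over with a fixed size, as only the earlier step lies beyond the scatter, and two instances can neither confirm a real drop on both cores nor reveal a dependence on the core.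

The compounds shown leave open how the read-out would respond to other groups at the same place on the aromatic ring, such as an ethyl chain, a chlorine atom or a carboxylic acid in place of the methyl. They also leave open how the change would read on any further core, and, with a single dose, how it would bear on potency.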